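Amide variation on the aminothiazole series: next replacement

The source may hold more compounds than are shown below. What is called first, only, known or untested is meant among the compounds shown, and "the series" means these compounds.

Measured so far:
compound 1 `CCCN(CC[C@H]1CC[C@H](NC(=O)/C=C/c2ccc(Cl)cc2)CC1)[C@H]1CCc2nc(N)sc2C1` — 2.5 nM
compound 2 `CCCN(CC[C@H]1CC[C@H](NC(=O)c2cccc3cnccc23)CC1)[C@H]1CCc2nc(N)sc2C1` — 5.9 nM

Two amides of the shared core are in hand. In an assay on brain for displacement of a labelled ligand from D(3) dopamine receptor (Rattus norvegicus) (a lower number here means a stronger inhibitor, a higher number a weaker inhibitor), compound 1 gives 2.5 nM, and compound 2 gives 5.9 nM. Within the data shown here, compound 2 therefore stands at the higher of the two numbers; the one step available is a 2.4-fold higher number from compound 1 to compound 2 (0.37 log units; beyond the scatter), a modest movement once the chlorophenyl-ethenyl group is exchanged for an aromatic bicycle on the carbonyl carbon.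

Compound 3 `CCCN(CC[C@H]1CC[C@H](NC(=O)c2ccc(-n3ccnc3)cc2)CC1)[C@H]1CCc2nc(N)sc2C1` is the next member. Its difference from compound 2 is 4-(1H-imidazol-1-yl)phenyl in place of isoquinolin-5-yl on a carbonyl carbon. Among the measured compounds shown here, only the step from compound 1 to compound 2 bears on this, and it showed that swapping one aromatic amide substituent for another moved the number only slightly. For compound 3 a step of about a 1.1-fold lower number from compound 2 to compound 3 (0.03 log units; within the scatter) is expected, in no particular direction beyond the scatter. Compound 3 is thus estimated at 5.5 nM, within 1.5 nM to 20 nM.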

Compound 3, inhibition constant: 1.9 nM
The estimate for compound 3 lay 2.9-fold (0.46 log units) above the measured number, within the range that was stated.
By their numbers in this assay, from the lowest: compounds 3 and 1 (each within the scatter of the next); then compound 2.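

In this assay the change from isoquinolin-5-yl to 4-(1H-imidazol-1-yl)phenyl on the carbonyl carbon gives a 3.1-fold lower number from compound 2 to compound 3 (0.49 log units; beyond the scatter) and so shows that a substituent with a different ring set can restore the lower numbers at this position. The other new step, a 1.3-fold lower number from compound 1 to compound 3 (0.12 log units; within the scatter), leaves 4-(1H-imidazol-1-yl)phenyl and 2-(4-chlorophenyl)ethenyl unordered, and among these three amides only isoquinolin-5-yl stands apart, with steps beyond the scatter to both others. Nothing at hand explains these differences.

From the compounds shown here alone, all three substituents carry an aromatic ring, so it remains open whether a cyclohexyl group, a plain alkyl chain or a carboxylic acid on the phenyl ring would hold such numbers. A plain phenyl group would show what the imidazol-1-yl ring contributes.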